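A five-membered ring in place of a six-membered ring

A few compounds are considered here, and "the series" means these few. Any claim that something is new, unique, unknown or untested is made for them only; others in the source may bear on it.

Readings in a functional assay on RPMI-8226 cells (Homo sapiens) for cytotoxicity, read by MTT assay, with a stated time of 72 h (a higher number here means a weaker inhibitor, a lower number a stronger inhibitor), for the measured compounds
Compound 1 `Cc1c(C)c2c(c(C)c1OC(=O)CCC(=O)NC1CC(C)(C)N([O])C(C)(C)C1)CC[C@@](C)(CCC[C@H](C)CCC[C@H](C)CCCC(C)C)O2` gives > 300000 nM as a limit
Compound 2 `Cc1c(C)c2c(c(C)c1O)CCC(C)(C(=O)NC1CC(C)(C)N([O])C(C)(C)C1)O2` gives 39000 nM as a value
Compound 3 `CC1(C)CC(CNC(=O)CCC(=O)O)C(C)(C)N1[O]` gives > 300000 nM as a limit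

Compound 1 stands at the limit of > 300000 nM in this assay, at which 2 of the 3 values shown sit, and so carries a limit, not a number. Compound 4 `Cc1c(C)c2c(c(C)c1OC(=O)CCC(=O)NC1CC(C)(C)N([O])C1(C)C)CC[C@@](C)(CCC[C@H](C)CCC[C@H](C)CCCC(C)C)O2` differs from it on an amide-type nitrogen, where a five-membered non-aromatic ring replaces a six-membered one, as a group of 10 heavy atoms (8 carbon, 1 nitrogen, 1 oxygen; one five-membered non-aromatic ring with 1 hetero atom) in place of a group of 11 heavy atoms (9 carbon, 1 nitrogen, 1 oxygen; one six-membered non-aromatic ring with 1 hetero atom), on an amide-type nitrogen shows. Going by the values given here, no measured pair shows this change. The expectation therefore rests on compound 1 with > 300000 nM as its limit. The expected a number no higher from compound 1 to compound 4 (the limit leaves the size open) is none beyond the scatter in this assay and has no expected direction. For compound 4 the expected value is 300000 nM within an estimated range of 120000 nM to 600000 nM and a limit reading is likely.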

Compound 4, half-maximal inhibitory concentration: 55000 nM
Compound 4: middle estimate off by 5.5-fold (0.74 log units), on the high side; the measured number lies below the stated range.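

In this assay, with the rest of the molecule unchanged, a five-membered non-aromatic ring in place of the six-membered one on an amide-type nitrogen gives an at least 5.4-fold lower number from compound 1 to compound 4 (0.73 log units; beyond the scatter), so this position responds to the ring change. Compound 4 gives 55000 nM, a measured number rather than a limit. The true size of the step stays unknown because its starting point is a limit: the limit of > 300000 nM in this assay, at which 2 of the 4 values shown sit.

From the compounds shown here alone, whether an open-chain amine or a longer chain on the amide-type nitrogen would give a similar reading stays open. So does whether the same ring change would act alike on the core of compound 2.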